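Swapping a Methoxy for a Bromophenyl on a Terpene Core

The compounds below may be only part of what the source reports. "The series", "measured", "known", "first", "only" and "open" are said of these compounds alone.

Measured compounds:
compound 1 `C=C[C@@](C)(/C=C/c1ccc(OC)cc1)CCC=C(C)C` — > 36600 nM
compound 2 `C=C[C@@](C)(/C=C/c1ccc(O)c(/C=C(\C)C(=O)OCC)c1)CCC=C(C)C` — > 36600 nM
compound 3 `COc1ccc(/C=C/[C@@](C)(/C=C/c2ccc(O)c(/C=C/C#N)c2)CCC=C(C)C)cc1` — 4540 nM

All three were tested in a functional assay on SEM cells (Homo sapiens) for cytotoxicity, with a stated time of 72 h; a higher number here means that more compound is needed for the effect, a lower number that less compound is needed. For compound 1 the result is a limit of the assay, not a number: > 36600 nM. Compound 2 likewise sits at a limit, > 36600 nM. Compound 1 therefore stands at the weak end of what is shown, at the limit of > 36600 nM in this assay, at which 2 of the 3 values shown sit. Only compound 3, with 4540 nM, gives an actual number in this assay.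

The unmeasured compound 4 `C=C[C@@](C)(/C=C/c1ccc(-c2cccc(Br)c2)cc1)CCC=C(C)C` differs from compound 1 in one place: 3-bromophenyl in place of methoxy on an aromatic carbon. For the measured compounds named here, no step between measured compounds is available to guide the size of this change, so the expectation rests on compound 1 alone. Because compound 1 gives only > 36600 nM, any change in this assay is expected to be a move from a limit toward a number, with its size uncertain. Compound 4 is estimated at 22000 nM, with a range of 6000 nM to 50000 nM; the step of an at least 1.6-fold lower number from compound 1 to compound 4 (0.22 log units; that floor lies within the scatter) is thus expected to be modest and toward lower values, though a limit remains possible.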

Compound 4, half-maximal effective concentration: > 36600 nM
Compound 4 was reported as a limit; the forecaster's own chance of this, stated with the estimate: 45%; at least 1.6-fold (0.22 log units) between middle value and limit.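

Compound 1 and compound 4 both sit at a limit rather than a number in this assay, so no step between them can be read: the limit of > 36600 nM in this assay, at which 3 of the 4 values shown sit.

The compounds shown leave open whether 3-bromophenyl in place of methoxy on an aromatic carbon changes the effect at all.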